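Piperazine nitrogen substituent in the CXCR4 antagonist series

This account rests on a few compounds, and the source may have more. Where it says the series, first, only, none or still open, it means among the compounds named here.

Measured compounds:
compound 1 `CN(C[C@H]1Cc2c(cccc2N2CCN(C3CC3)CC2)CN1)[C@H]1CCCc2cccnc21`, 23.5 nM
compound 2 `CN1CCN(c2cccc3c2C[C@H](CN(C)[C@H]2CCCc4cccnc42)NC3)CC1`, 29.6 nM

In a functional assay on CCRF-CEM cells for antagonist activity at C-X-C chemokine receptor type 4 (Homo sapiens), read by calcium flux, with stated times of 25 min and 90 s (on this read-out higher numbers stand for weaker inhibition and lower numbers for stronger inhibition), compound 2 gives 29.6 nM and stands alongside compound 1, the two within the scatter of each other. Compound 3 `CN(C[C@H]1Cc2c(cccc2N2CCN(c3ncccn3)CC2)CN1)[C@H]1CCCc2cccnc21` carries pyrimidin-2-yl in place of methyl on an amine nitrogen in a ring. Within the data shown here, the only step measured at this site is a 1.3-fold higher number from compound 1 to compound 2 (0.10 log units; within the scatter), a small exchange that left the number essentially unchanged. Among the measured compounds shown here, no measured step covers an aromatic group entering here, so the expectation rests on that step alone: compound 3 is expected to show no shift beyond the scatter, a 1.0-fold higher number from compound 2 to compound 3 (0.01 log units; within the scatter). The estimate for compound 3 is 30 nM, with a range from 12 nM to 75 nM.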

Compound 3, half-maximal inhibitory concentration: 30.7 nM
Estimate against measurement, compound 3: 1.0-fold (0.01 log units) below, and the stated range covers the measured number.
By their numbers in this assay, from the lowest: compounds 1, 2 and 3 (each within the scatter of the next).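

In this assay, an aromatic group on this amine nitrogen in a ring reads the same as the small groups: pyrimidin-2-yl in place of methyl gives a 1.0-fold higher number from compound 2 to compound 3 (0.02 log units; within the scatter), and pyrimidin-2-yl in place of cyclopropyl gives a 1.3-fold higher number from compound 1 to compound 3 (0.12 log units; within the scatter). The position thus accepts a six-membered aromatic ring with 2 hetero atoms without the number leaving the scatter. Nothing available accounts for this result. On these data alone, whether a carboxylic acid, a primary amine or a longer chain on this nitrogen would move the number remains open. Also open, as far as these compounds go, is whether a phenyl ring would read the same as pyrimidin-2-yl.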